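The source may report more compounds than this note shows. Statements on the series, on what has been measured and on what is new or still open speak of the compounds shown alone.

In an ADME assay on a cell-free system (plasma, Rattus norvegicus) for metabolic stability, read by LC-MS, with a stated time of 60 min, tested at 100 uM (on this read-out higher numbers stand for a more stable compound and lower numbers for a less stable compound), compound 1 `Cc1c(OCCCCOc2ccc(C(=O)O)cc2Cl)ccc(C(=O)CC2CCCC2)c1O` gives 120% and compound 2 `Cc1c(OCCCCOc2cccc(C(=O)O)c2)ccc(C(=O)CC2CCCC2)c1O` gives 99% as the lower of the two numbers. Compound 3 `COc1ccc(C(=O)O)cc1OCCCCOc1ccc(C(=O)CC2CCCC2)c(O)c1C` differs from compound 2 by methoxy in place of hydrogen on an aromatic carbon with methoxy in place of hydrogen on an aromatic carbon. Among the measured compounds shown here, the only measured step is a number 21 percentage points lower from compound 1 to compound 2 (beyond the scatter) with 3-carboxyphenyl in place of 4-carboxy-2-chlorophenyl, and it involves no methoxy, so it bears only loosely on this change. On that slim evidence, the expected step is a number 5 percentage points higher from compound 2 to compound 3 (within the scatter) and of small size, probably not beyond the scatter. Compound 3 is estimated at 104% with a range from 86% to 122% expected on repeat measurement.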

Compound 3, percent of the compound remaining: 103%
The estimate for compound 3 lay 1 percentage points above the measured number, within the range that was stated.
By their numbers in this assay, from the lowest: compounds 2 and 3 (each within the scatter of the next); then compound 1.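

In this assay, methoxy in place of hydrogen on this aromatic carbon, ortho to a large group and para to a carboxy group, leaves the read-out unmoved beyond the scatter, with a number 4 percentage points higher from compound 2 to compound 3 (within the scatter). The 5-carboxy-2-methoxyphenyl group still differs from the 4-carboxy-2-chlorophenyl group, with a number 17 percentage points lower from compound 1 to compound 3 (beyond the scatter), so methoxy here does not recover the number of compound 1. Nothing available explains either step. Open, on these data alone, is how a hydroxy group, an ethoxy group or an amine would read on this same carbon. Also open, as far as these compounds go, is whether the methoxy step holds with a longer chain.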